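Aryl variation on the piperazine nitrogen: step to compound 4

The compounds below may be only part of what the source reports. "The series", "measured", "known", "first", "only" and "open" are said of these compounds alone.

Compound 3 `Nc1scc(CN2CCN(c3ccncc3)CC2)c1C(=O)c1ccc(Cl)cc1` gives 1.4% in a functional assay on CHO cells with adenosine receptor A1 (Homo sapiens) as the target, read by cAMP accumulation and immunoassay, with a stated time of 6 min, tested at 0.1 uM; a higher number here means a weaker effect of the compound at the concentration tested, a lower number a stronger effect. It stands second highest of the three numbers: compound 1 `Nc1scc(CN2CCN(c3cccc(Cl)c3Cl)CC2)c1C(=O)c1ccc(Cl)cc1` gives 3.2% in this assay, within the scatter of compound 3 as a number 1.8 percentage points lower from compound 1 to compound 3 (within the scatter) shows, while compound 2 `Nc1scc(CN2CCN(c3cc(Cl)cc(Cl)c3)CC2)c1C(=O)c1ccc(Cl)cc1` gives -22% in this assay, and the step of a number 23.4 percentage points higher from compound 2 to compound 3 (beyond the scatter) is beyond the scatter.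

Compound 4 `Nc1scc(CN2CCN(c3cccc(F)c3)CC2)c1C(=O)c1ccc(Cl)cc1` differs from compound 3 by 3-fluorophenyl in place of pyridin-4-yl on an amine nitrogen in a ring. Going by the values given here, the steps that bear on this change are the exchanges of the group on the same ring nitrogen: a number 1.8 percentage points lower from compound 1 to compound 3 (within the scatter) was flat, a number 25.2 percentage points lower from compound 1 to compound 2 (beyond the scatter) and a number 23.4 percentage points higher from compound 2 to compound 3 (beyond the scatter) were modest and point in opposite directions. Two of three aryl groups tried give numbers near zero, one gives a clearly lower number, so the range must admit a drop.

The expectation is a step of a number 1.4 percentage points lower from compound 3 to compound 4 (within the scatter), within the scatter, because compound 1 3.2% and compound 3 1.4% sit close together. Compound 4 is estimated at 0%, with a range from -20% to 12% to cover a drop like that of compound 2.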

Compound 4, a percentage reported as activity, at one concentration (the size of the read-out at that concentration, not a potency): -37%
For compound 4 the middle estimate is 37 percentage points above the measured one, and the stated range ends above it.
By their numbers in this assay, from the lowest: compound 4; then compound 2; then compounds 3 and 1 (each within the scatter of the next).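

In this assay, going by these compounds alone, the group on the ring nitrogen can move the read-out much further than the earlier compounds showed: a number 38.4 percentage points lower from compound 3 to compound 4 (beyond the scatter) and a number 40.2 percentage points lower from compound 1 to compound 4 (beyond the scatter) are both large. The low end of the range is also not a single level, since a number 15 percentage points lower from compound 2 to compound 4 (beyond the scatter) separates 3-fluorophenyl from 3,5-dichlorophenyl, and a halogen-bearing phenyl does not by itself give a low number, as compound 1 with 2,3-dichlorophenyl stands at 3.2% in the same assay. No measurement among these compounds accounts for these steps.

Going by these compounds, whether unsubstituted phenyl, 3-chlorophenyl or 3-methoxyphenyl on the same ring nitrogen would give a number as low as that of compound 4 remains open. A read-out at one concentration also leaves the potency of these compounds open.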